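This account rests on a few compounds, and the source may have more. Where it says the series, first, only, none or still open, it means among the compounds named here.

Compound 1 `CN1CCC(NC(=O)c2ccc(Cn3nc(-c4cnn(C)c4)c4ccccc4c3=O)cc2)CC1` and compound 2 `Cc1noc(C)c1-c1nn(Cc2ccc(C(=O)N3CCCCC3)cc2)c(=O)c2ccccc12` share a core and have both been tested in a functional assay on HepG2 cells (Homo sapiens) for antiproliferative activity, read by MTT assay, with a stated time of 72 h; on this read-out higher numbers stand for weaker inhibition and lower numbers for stronger inhibition. In this assay compound 1 gives 47300 nM, while compound 2 gives 97300 nM; of these two numbers, compound 1 holds the lower one, and the gap between them lies beyond the usual scatter. The two compounds differ in more than one place, so this gap cannot be tied to any single change. Compound 3 `Cn1cc(-c2nn(Cc3ccc(C(=O)NC4CC4)cc3)c(=O)c3ccccc23)cn1` has not yet been measured. It differs from compound 1 at one place only: cyclopropyl in place of 1-methylpiperidin-4-yl on an amide-type nitrogen. Going by the values given here, no measured pair shows this same change, so its effect is unknown. Because compound 1 already gives 47300 nM, compound 3 is expected to stay in a similarly weak range, with a step of a 1.3-fold higher number from compound 1 to compound 3 (0.10 log units; within the scatter) estimated as small and toward a somewhat higher number. Compound 3 is thus expected to give about 60000 nM, within a range from 20000 nM to 200000 nM.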

Compound 3, half-maximal inhibitory concentration: > 100000 nM
Compound 3 gave a limit, no number; the forecaster's own chance of this, stated with the estimate: 15%; at least 1.6-fold (0.22 log units) between middle value and limit.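

In this assay, going by these compounds alone, the group on the amide-type nitrogen can now be read as a single change for the first time: cyclopropyl in place of 1-methylpiperidin-4-yl gives an at least 2.1-fold higher number from compound 1 to compound 3 (0.32 log units; beyond the scatter). The result for compound 3 is a limit of the assay, not a number: the limit of > 100000 nM in this assay, at which 1 of the 3 values shown sits.

Compound 1 and compound 2 differ in more than one place, so they could not show that this group alone shifts the read-out, here toward weaker inhibition with cyclopropyl.

The two groups compared differ in both ring size and the presence of a nitrogen, so the compounds shown do not tell which of these matters. A cyclohexyl group, or a 2-(dimethylamino)ethyl chain, on the same nitrogen would help to separate the two.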